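The source may hold more compounds than are shown below. What is called first, only, known or untested is meant among the compounds shown, and "the series" means these compounds.

Compound 1 `NC(=O)C[C@H](NC(=O)CN(c1nc(Cl)nc2[nH]cnc12)C1CC1)C(=O)O`, compound 2 `CC(C)[C@H](NC(=O)CN(c1nc(Cl)nc2[nH]cnc12)C1CC1)C(=O)O` and compound 3 `NC(=O)CC[C@H](NC(=O)CN(c1nc(Cl)nc2[nH]cnc12)C1CC1)C(=O)OCc1ccccc1` were tested in a functional assay on the whole organism (Tail, strain ICR) with Mus musculus as the target, in the tail flick test, with a stated time of 30 min, at a dose of 25 umol/kg by the oral route; on this read-out lower numbers stand for a weaker effect and higher numbers for a stronger effect at the one dose given. Compound 1 gives 29.7%, compound 2 gives 31.2% and compound 3 gives 30.8%. Compound 2 differs from compound 1 by isopropyl in place of carbamoylmethyl on a saturated chain carbon bound to an amide-type nitrogen and a carbonyl carbon, a change that gave a number 1.5 percentage points higher from compound 1 to compound 2 (within the scatter). The difference between the core of compound 1 and the core of compound 3 is not broken down here. Compound 4 `CC(C)C[C@H](NC(=O)CN(c1nc(Cl)nc2[nH]cnc12)C1CC1)C(=O)OCc1ccccc1` is not yet measured; it differs from compound 3 by isopropyl in place of carbamoylmethyl on a saturated chain carbon, two bonds along the chain from an amide-type nitrogen and a carbonyl carbon. This is the same kind of change, though its place differs: on a saturated chain carbon bound to an amide-type nitrogen and a carbonyl carbon in the first case, on a saturated chain carbon two bonds along the chain from an amide-type nitrogen and a carbonyl carbon in the second. A step of similar size, a number 1.2 percentage points higher from compound 3 to compound 4 (within the scatter), is expected because a number 1.5 percentage points higher from compound 1 to compound 2 (within the scatter) lies within the scatter. Compound 4 is therefore estimated at 32%, between 22% and 42%.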

Compound 4, a percentage reported as activity, at one dose (the size of the read-out at that dose, not a potency): 33.9%
Beside the measured number, compound 4's estimate is 1.9 percentage points below it; the measured number falls inside the stated range.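

In this assay the exchange of carbamoylmethyl for isopropyl gave a number 3.1 percentage points higher from compound 3 to compound 4 (within the scatter), and the earlier step agrees with it: the same change on two cores in this assay, a number 1.5 percentage points higher (within the scatter) from compound 1 to compound 2 and a number 3.1 percentage points higher (within the scatter) from compound 3 to compound 4, 1.6 percentage points apart, within the scatter of two such steps. Going by these compounds alone, on these two cores, the change therefore carries over with no step that stands out from the scatter. This does not show that the change strengthens the effect, as neither step lies beyond the scatter, and two cores say nothing about a third.

The compounds shown leave open whether another group in this place, such as an amine, a carboxylic acid or a longer chain, would move the read-out beyond the scatter. They also leave open how the change behaves at other doses or times.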